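Styryl in Place of Furan: Expected Cytotoxicity Shift

The source may hold more compounds than are shown below. What is called first, only, known or untested is meant among the compounds shown, and "the series" means these compounds.

Measured compounds:
Compound 1, `O=CCN1N=C(c2ccc3ccccc3c2)CC1c1ccccc1[N+](=O)[O-]` — 3010 nM
Compound 2, `O=CCN1N=C(c2ccc3ccccc3c2)CC1c1ccco1` — 23000 nM

Both compounds share one core and differ only in the group on a saturated ring carbon. In a functional assay on PC-3 cells (Homo sapiens) for cytotoxicity, read by sulforhodamine B assay, with a stated time of 48 h (on this read-out lower numbers stand for stronger inhibition and higher numbers for weaker inhibition), compound 1 gives 3010 nM, and compound 2 gives 23000 nM. Compound 2 thus stands at the higher, weaker end of the two numbers, separated from compound 1 by a 7.6-fold higher number from compound 1 to compound 2 (0.88 log units; beyond the scatter).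

Compound 3, `O=CCN1N=C(c2ccc3ccccc3c2)CC1/C=C/c1ccccc1`, has not been measured. It arises from compound 2 by 2-phenylethenyl in place of furan-2-yl on a saturated ring carbon.

Within the data shown here, only one measured step bears on this change: a 7.6-fold higher number from compound 1 to compound 2 (0.88 log units; beyond the scatter), which shows that swapping the group on this carbon can move the number clearly beyond the scatter. The new 2-phenylethenyl group, like the 2-nitrophenyl of compound 1, carries a six-membered carbon ring, so the number for compound 3 is expected to move back down from compound 2 rather than up. The estimated step is a 2.9-fold lower number from compound 2 to compound 3 (0.46 log units; beyond the scatter). Compound 3 is therefore expected to give about 8000 nM in this assay, with a plausible range from 2500 nM to 25000 nM.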

Compound 3, half-maximal inhibitory concentration: 19100 nM
Compound 3: middle estimate off by 2.4-fold (0.38 log units), on the low side; low and high end bracket the measured number.
By their numbers in this assay, from the lowest: compound 1; then compounds 3 and 2 (each within the scatter of the next).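

In this assay the swap of furan-2-yl for 2-phenylethenyl gives a 1.2-fold lower number from compound 2 to compound 3 (0.08 log units; within the scatter), so at this saturated ring carbon the two groups cannot be told apart, even though the entering group is larger and has a six-membered aromatic ring of carbon only. The other new step, a 6.3-fold higher number from compound 1 to compound 3 (0.80 log units; beyond the scatter), shows that a six-membered carbon ring in the group is not enough to reach the level of compound 1: of the three groups, only 2-nitrophenyl stands apart, with steps beyond the scatter to both of the others. Nothing at hand explains why this group differs from the other two.

The compounds shown leave open whether the nitro group or the ring joined directly to this carbon matters more; a plain phenyl, or a phenyl carrying an amine or a carboxylic acid in place of the nitro group, would help separate the two. Also open, from the compounds shown here alone, is how a group with no ring at all, such as a short alkyl chain, would behave at this carbon.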